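Isobutyl to tert-butyl ester on two related cores

A few compounds are considered here, and "the series" means these few. Any claim that something is new, unique, unknown or untested is made for them only; others in the source may bear on it.

Compound 1 `CC1=C(C(=O)OCC(C)C)C(c2ccco2)NC(=S)N1`: 18%
Compound 2 `CC1=C(C(=O)OC(C)(C)C)C(c2ccco2)NC(=S)N1`: 9%
Compound 3 `CC1=C(C(=O)OCC(C)C)C(c2ccoc2)NC(=O)N1C`: 1%

All three were tested in an assay on membranes from HEK293 cells for displacement of a labelled ligand from adenosine receptor A2b (Homo sapiens), read by scintillation counting, with a stated time of 30 min, tested at 1 uM; a higher number here means more inhibition at the concentration tested (going by the name of the read-out), a lower number less inhibition. Compound 1 gives 18% and compound 2 gives 9%; the change between them is tert-butyl in place of isobutyl on an oxygen next to a carbonyl group and it made a step of a number 9 percentage points lower from compound 1 to compound 2 (within the scatter). Compound 3, which carries a different core, gives 1%; the difference between the core of compound 3 and the core of compound 1 is not broken down here.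

Compound 4 `CC1=C(C(=O)OC(C)(C)C)C(c2ccoc2)NC(=O)N1C` has not been measured. It differs from compound 3 by tert-butyl in place of isobutyl on an oxygen next to a carbonyl group, the same change as from compound 1 to compound 2, at the same place. Because the earlier step was a number 9 percentage points lower from compound 1 to compound 2 (within the scatter) and compound 3 gives 1%, compound 4 is expected to show a step of about no change at the digits printed from compound 3 to compound 4 (within the scatter) in this assay. Compound 4 is therefore estimated at 1%, with a likely range from -9% to 11%.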

Compound 4, a percentage reported as inhibition, at one concentration (the size of the read-out at that concentration, not a potency): 16%
The estimate for compound 4 lay 15 percentage points below the measured number; measured number above the stated range.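

On the core of compound 3, tert-butyl in place of isobutyl gave a number 15 percentage points higher from compound 3 to compound 4 (beyond the scatter) in this assay. Set beside the earlier step, the change did not carry over from one core to the other: the same change on two cores in this assay, a number 9 percentage points lower (within the scatter) from compound 1 to compound 2 and a number 15 percentage points higher (beyond the scatter) from compound 3 to compound 4, 24 percentage points apart, beyond the scatter of two such steps This shows that, in this series, the step read on the core of compound 1 could not simply be transferred to the core of compound 3, but it does not show which difference between the two cores goes with the gap, and it rests on one pair per core, each read at one concentration and giving no potency.

The compounds shown leave open whether a methyl ester, an ethyl ester or a longer chain on the same oxygen, or a carboxylic acid or an amide in place of the ester, would follow either step. They also leave open how the change behaves on a core that differs from that of compound 1 in one place only.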